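Swapping Phenoxy for Ethyl on a Sulfonamide Series

This account rests on a few compounds, and the source may have more. Where it says the series, first, only, none or still open, it means among the compounds named here.

Compound 1, `O=C1NCCN1c1ccc(S(=O)(=O)Nc2ccc(C3CCCCC3)cc2)cc1`: > 1000 nM
Compound 2, `O=C1NCCN1c1ccc(S(=O)(=O)Nc2cccc(Oc3ccccc3)c2)cc1`: 200 nM
Compound 3, `CC(C)(C)c1cc(NS(=O)(=O)c2ccc(N3CCNC3=O)cc2)cc(C(C)(C)C)c1`: > 1000 nM

Of the compounds shown here, three sharing one core have been tested in a functional assay on HT-29 cells (Homo sapiens) for antiproliferative activity, read by sulforhodamine B assay, with a stated time of 48 h; on this read-out higher numbers stand for weaker inhibition and lower numbers for stronger inhibition. Among the measured compounds shown here, compound 2 gives 200 nM, the only true number among the three. For compound 1 the read-out is a limit of the assay, > 1000 nM. For compound 3 the read-out is likewise a limit, > 1000 nM. Compound 2 therefore stands alone with a measured number, while the other two rest at the limit of > 1000 nM in this assay, at which 2 of the 3 values shown sit. For the measured compounds named here, no pair of the measured compounds differs in a single place, so no measured step between them can be drawn.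

Compound 4, `CCc1cccc(NS(=O)(=O)c2ccc(N3CCNC3=O)cc2)c1`, awaits measurement. It differs from compound 2 by ethyl in place of phenoxy on an aromatic carbon. Among the measured compounds only compound 2, which carries the phenoxy, yields a number; compound 1 and compound 3 carry other groups on the same ring and sit at the limit. The step expected in this assay is toward weaker inhibition, of moderate size and likely beyond the scatter, and the estimated step is a 3.0-fold higher number from compound 2 to compound 4 (0.48 log units; beyond the scatter). Compound 4 is expected to give 600 nM, with a range from 200 nM to 3000 nM, and a fair chance that only a limit is returned.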

Compound 4, half-maximal inhibitory concentration: 110 nM
Beside the measured number, compound 4's estimate is 5.5-fold (0.74 log units) above it; measured number outside the range, below it.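

In this assay, ethyl in place of phenoxy gives a 1.8-fold lower number from compound 2 to compound 4 (0.26 log units; within the scatter), so the two compounds cannot be told apart on this read-out. Among the compounds shown here, this is the first comparison that isolates a single position, on an aromatic carbon and meta to a large group, and it shows that a measured number there does not depend on the phenoxy: ethyl has no ring and no hydrogen-bond acceptor, yet the result stays within the scatter. It also gives the series a second true number, whereas the other values shown are limits of the assay and not numbers: the limit of > 1000 nM in this assay, at which 2 of the 4 values shown sit.

As far as these compounds go, what remains open is whether this position accepts other groups as readily, for instance a methyl, a longer chain such as butyl, an amine or a carboxylic acid, or whether the result holds only for the two groups compared here. From the compounds shown here alone, since the comparison rests on one pair in one cell assay, it also remains open whether the same exchange would behave alike on another read-out.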